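The compounds below may be only part of what the source reports. "The series", "measured", "known", "first", "only" and "open" are said of these compounds alone.

Measured so far in a functional assay on HL-60 cells (Homo sapiens) for cytotoxicity, read by luminescence and CellTiter-Glo, with a stated time of 3 days; on this read-out higher numbers stand for weaker inhibition and lower numbers for stronger inhibition
- compound 1 `N#Cc1ccc(NC(=O)c2ccc(Cl)cc2O)cc1` gives 1300 nM
- compound 2 `Cc1ccc(C(=O)Nc2ccc(C#N)cc2)c(O)c1` gives 2420 nM
- compound 3 `O=C(Nc1ccc(C(F)(F)F)cc1)c1cc(F)ccc1O` gives 490 nM

Compound 2 at 2420 nM lies within the scatter of compound 1 at the upper end of these numbers, and compound 3 at 490 nM shows a clearly lower number than compound 2 does.

The next compound to be read is compound 4 `N#Cc1ccc(NC(=O)c2ccc(-c3cccnc3)cc2O)cc1`. It carries pyridin-3-yl in place of methyl on an aromatic carbon of compound 2 (pyridin-3-yl in place of methyl on an aromatic carbon). That carbon is meta to a hydroxy group and para to a large group.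

For the measured compounds named here, only one measured step touches this place, a 1.9-fold higher number from compound 1 to compound 2 (0.27 log units; within the scatter), with methyl in place of chloro. It stays within the scatter. Going by the values given here, compound 3 differs from the others in more than one place and offers no step here. Among the compounds with values here, no compound yet carries a ring at this carbon, so the step from chloro to methyl is weak guidance for a change this large, and the range has to stay wide.

No shift beyond the scatter is expected in this assay, and any lean is slightly towards a lower number. The expected step is a 1.6-fold lower number from compound 2 to compound 4 (0.21 log units; within the scatter). For compound 4 the estimated value is 1500 nM, with an expected range from 400 nM to 6000 nM.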

Compound 4, half-maximal inhibitory concentration: 6660 nM
The estimate for compound 4 lay 4.4-fold (0.65 log units) below the measured number, and the stated range ends below it.
By their numbers in this assay, from the lowest: compound 3; then compounds 1 and 2 (each within the scatter of the next); then compound 4.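

In this assay this carbon, meta to a hydroxy group and para to a large group, now gives steps beyond the scatter: pyridin-3-yl in place of methyl gives a 2.8-fold higher number from compound 2 to compound 4 (0.44 log units; beyond the scatter) and pyridin-3-yl in place of chloro gives a 5.1-fold higher number from compound 1 to compound 4 (0.71 log units; beyond the scatter) as well, both modest, whereas the exchange of chloro for methyl (a 1.9-fold higher number from compound 1 to compound 2 (0.27 log units; within the scatter)) stayed within it. Among compounds 1, 2 and 4, the position therefore separates a six-membered aromatic ring from the two single-atom-sized groups, and the direction is towards weaker inhibition, though this rests on a single ring example. Nothing available explains this shift on the cytotoxicity read-out.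

Going by these compounds, whether the step belongs to the ring itself or to its nitrogen stays open, and a plain phenyl ring at this carbon would separate the two, while a small amine or a carboxylic acid there would show how the position responds to groups other than rings. Also open, on these data alone, is whether the same step would hold with trifluoromethyl in place of the nitrile, since compound 3 differs from compound 4 in more than one place.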